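The source may hold more compounds than are shown below. What is called first, only, known or untested is meant among the compounds shown, and "the series" means these compounds.

Measured so far in an ADME assay on a cell-free system (plasma, Rattus norvegicus, strain Wistar Han) for protein binding:
compound 1 (`CCC(=O)N1CC[C@H](Nc2ncnc3c2nc(-c2cnn(CC)c2C)n3C)C1`) gives 51%
compound 2 (`CCn1ncc(-c2nc3c(N[C@H]4CCN(C(=O)C5CC5)C4)ncnc3n2C)c1C`) gives 72%

On these numbers, compound 2 stands within the scatter of compound 1, so the pair does not separate firmly. Compound 3 (`CCn1ncc(-c2nc3c(N[C@H]4CCN(C(=O)C5CCOCC5)C4)ncnc3n2C)c1C`) follows from compound 2 with oxan-4-yl in place of cyclopropyl on a carbonyl carbon. For the measured compounds named here, the one measured step that bears on this change sits at the same place, cyclopropyl in place of ethyl on a carbonyl carbon (a 1.8-fold lower unbound fraction from compound 1 to compound 2 (0.24 log units; within the scatter)). Going by the values given here, no measured compound carries oxan-4-yl, so that step is only a weak guide. No shift beyond the scatter is expected in this assay for this change, with a slight lean towards more free compound. The expected step is small (a 1.4-fold higher unbound fraction from compound 2 to compound 3 (0.13 log units; within the scatter)). Compound 3 is estimated at 62% (expected range 42% to 78%).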

Compound 3, plasma protein binding: 48%
Compound 3: middle estimate off by 1.4-fold (0.14 log units) (unbound fraction), on the low side; measured number inside the range.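

On the carbonyl carbon bonded to the ring amide nitrogen, a third group can now be read in this assay: oxan-4-yl in place of cyclopropyl gives no firm separation (a 1.9-fold higher unbound fraction from compound 2 to compound 3 (0.27 log units; within the scatter)), and neither does oxan-4-yl in place of ethyl (a 1.1-fold higher unbound fraction from compound 1 to compound 3 (0.03 log units; within the scatter)). Ethyl, cyclopropyl and oxan-4-yl are therefore not separated at this position, even though oxan-4-yl brings a six-membered ring with a hetero atom and a hydrogen-bond acceptor. Nothing available accounts for the small differences among these compounds.

Still open, going by these compounds, is whether an amine or a carboxylic acid on this carbonyl carbon would give a step beyond the scatter in this assay. Also open, on these data alone, is whether a longer chain there would stay as close to ethyl as oxan-4-yl does.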